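The compounds below may be only part of what the source reports. "The series", "measured", "known", "first", "only" and "open" are said of these compounds alone.

Of the compounds shown here, three sharing one core have been read in a functional assay on HepG2 cells (Homo sapiens) for antiproliferative activity, read by MTT assay, with a stated time of 48 h; on this read-out lower numbers stand for an effect already at smaller amounts and higher numbers for an effect only at larger amounts of compound. Compound 1 `CC1=NN(S(=O)(=O)c2ccc([N+](=O)[O-])cc2)C(c2cc(Br)ccc2O)C1` stands at > 60000 nM, which is a limit of the assay and not a number. Compound 2 `CC1=NN(S(=O)(=O)c2ccc(F)cc2)C(c2cc(Br)ccc2O)C1` gives 50100 nM. Compound 3 `CC1=NN(S(=O)(=O)c2ccc(Cl)cc2)C(c2cc(Br)ccc2O)C1` stands at > 60000 nM, which is also a limit and not a number. The series thus lies close to the limit of > 60000 nM in this assay, at which 2 of the 3 values shown sit.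

Compound 4 `CC1=NN(S(=O)(=O)c2ccc(C(F)(F)F)cc2)C(c2cc(Br)ccc2O)C1` is the next case, and it departs from compound 3 by trifluoromethyl in place of chloro on an aromatic carbon. In words, this is trifluoromethyl in place of chloro on an aromatic carbon, para to a large group.

The measured exchanges of this same substituent bear on it: an at least 1.1-fold lower number from compound 1 to compound 2 (0.07 log units; that floor lies within the scatter), an at least 1.1-fold higher number from compound 2 to compound 3 (0.07 log units; that floor lies within the scatter), and a step that the two limits leave unreadable from compound 1 to compound 3. None of these shows a change beyond the scatter, so no step beyond the scatter is expected in this assay, and a report of only a limit is quite possible. The expected outcome is a number no higher from compound 3 to compound 4 (the limit leaves the size open). For compound 4 the estimated value is 60000 nM, with an expected range of 30000 nM to 120000 nM.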

Compound 4, half-maximal effective concentration: 22100 nM
For compound 4 the middle estimate is 2.7-fold (0.43 log units) above the measured one; the whole stated range lies above it.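

Going by these compounds alone, at the aromatic carbon para to a large group, trifluoromethyl gives the first steps beyond the scatter in this assay: a 2.3-fold lower number from compound 2 to compound 4 (0.36 log units; beyond the scatter); an at least 2.7-fold lower number from compound 3 to compound 4 (0.43 log units; beyond the scatter); an at least 2.7-fold lower number from compound 1 to compound 4 (0.43 log units; beyond the scatter). Within the data shown here, only the step from the fluoro compound has a fixed size, and the other two are floors because compound 1 and compound 3 each stand at a limit of the assay and not at a number: the limit of > 60000 nM in this assay, at which 2 of the 4 values shown sit. Chloro and trifluoromethyl both have 0 hydrogen-bond donors, 0 hydrogen-bond acceptors and no net charge, so this step appears without any change in those counts, while the heavy atoms go from 1 to 4.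

Which feature of trifluoromethyl goes with the lower number stays open with only four substituents in hand. Also open, on these data alone, is how an amine, a carboxylic acid or a longer alkyl chain would read at this place, and whether the step holds with other changes on the shared core.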